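The source may hold more compounds than are shown below. What is called first, only, known or untested is meant among the compounds shown, and "the series" means these compounds.

Compound 3 `Cn1ncc(Cl)c1-c1cc(C(=O)N[C@@H]2CN[C@H](CCN3CCC(O)CC3)C[C@H]2c2ccc(Cl)c(Cl)c2)oc1Cl` carries the highest number of the three compounds measured in a functional assay on HCT-116 cells (Homo sapiens) for antiproliferative activity, read by sulforhodamine B assay, with a stated time of 72 h; on this read-out lower numbers stand for stronger inhibition and higher numbers for weaker inhibition: compound 3 gives 13700 nM. Compound 1 `CNC(=O)C[C@@H]1C[C@@H](c2ccc(Cl)c(Cl)c2)[C@H](NC(=O)c2cc(-c3c(Cl)cnn3C)c(Cl)o2)CN1` gives 450 nM, and compound 2 `Cn1ncc(Cl)c1-c1cc(C(=O)N[C@@H]2CN[C@H](CCNS(C)(=O)=O)C[C@H]2c2ccc(F)c(F)c2)oc1Cl` gives 920 nM, both well apart from compound 3. Compound 4 `Cn1ncc(Cl)c1-c1cc(C(=O)N[C@@H]2CN[C@H](CCn3cncn3)C[C@H]2c2ccc(Cl)c(Cl)c2)oc1Cl` has not yet been measured. It differs from compound 3 in one place: 1H-1,2,4-triazol-1-yl in place of 4-hydroxypiperidin-1-yl on a saturated chain carbon, two bonds along the chain from a saturated ring carbon. Among the compounds with values here, the one step that touches the same region of the shared core is a 30-fold higher number from compound 1 to compound 3 (1.48 log units; beyond the scatter), a large movement that shows how much this assay responds to what hangs on that chain. Within the data shown here, no measured pair compares the triazolyl group with the hydroxypiperidinyl group directly, so the direction of the new step is uncertain, but the large swing already seen leaves room for a move either way. Compound 4 is therefore expected to return a number somewhat lower than compound 3, with the step estimated as a 3.4-fold lower number from compound 3 to compound 4 (0.53 log units; beyond the scatter). The estimate for compound 4 is 4000 nM, within a range from 800 nM to 20000 nM.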

Compound 4, half-maximal inhibitory concentration: 560 nM
For compound 4 the middle estimate is 7.1-fold (0.85 log units) above the measured one, outside the stated range (below it).
By their numbers in this assay, from the lowest: compounds 1, 4 and 2 (each within the scatter of the next, the first and the last beyond it); then compound 3.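

In this assay, 1H-1,2,4-triazol-1-yl in place of 4-hydroxypiperidin-1-yl gives a 24-fold lower number from compound 3 to compound 4 (1.39 log units; beyond the scatter), so the weak result of compound 3 is tied to the group on this chain and not to the 2-substituted ethyl chain as such. The further step, a 1.2-fold higher number from compound 1 to compound 4 (0.09 log units; within the scatter), lies within the scatter, so (1H-1,2,4-triazol-1-yl)methyl and methylcarbamoyl cannot be told apart here, and among these three compounds with the dichlorophenyl group only compound 3 stands apart. Nothing in the data shown explains the size of the step from the hydroxypiperidine to the triazole.

From the compounds shown here alone, it remains open whether the loss follows the hydroxyl or the piperidine ring itself, which a plain piperidin-1-yl on the same chain carbon would separate. Going by these compounds, how a 1H-imidazol-1-yl or a carboxylic acid would read at this place also remains open.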